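The source may hold more compounds than are shown below. What is called first, only, known or untested is meant among the compounds shown, and "the series" means these compounds.

In a functional assay on CHO cells for agonist activity at Alpha-1A adrenergic receptor (Homo sapiens), read by FLIPR and calcium flux (on this read-out higher numbers stand for an effect only at larger amounts of compound and lower numbers for an effect already at smaller amounts), compound 1 `COc1c(C)ccc2c1CCC2c1ncc[nH]1` gives 167 nM, compound 2 `COc1cccc2c1CCC2c1ncc[nH]1` gives 32 nM, and compound 3 `Clc1ccc2c(c1-c1ccn[nH]1)CCC2c1ncc[nH]1` gives 322 nM.

Compound 3 has the highest number of the three; its gap to compound 1 is within the scatter, its gap to compound 2 beyond it. Compound 4 `COc1c(Cl)ccc2c1CCC2c1ncc[nH]1` arises from compound 3 by methoxy in place of 1H-pyrazol-5-yl on an aromatic carbon. For the measured compounds named here, no measured step matches this swap. Going by the values given here, the one measured step, a 5.2-fold lower number from compound 1 to compound 2 (0.72 log units; beyond the scatter), shows that a small change on the same ring of the shared core can shift the number modestly. Compound 4 carries the methoxy of compounds 1 and 2, so its value is expected to fall near theirs. Compound 4 is therefore estimated at 80 nM, with a range from 25 nM to 250 nM, an expected step of a 4.0-fold lower number from compound 3 to compound 4 (0.60 log units; beyond the scatter).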

Compound 4, half-maximal effective concentration: 451 nM
Compound 4: middle estimate off by 5.6-fold (0.75 log units), on the low side; the whole stated range lies below it.
By their numbers in this assay, from the lowest: compound 2; then compounds 1, 3 and 4 (each within the scatter of the next, the first and the last beyond it).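

In this assay, with the chloro group kept, methoxy and 1H-pyrazol-5-yl cannot be told apart on an aromatic carbon: a 1.4-fold higher number from compound 3 to compound 4 (0.15 log units; within the scatter). With methoxy kept, the group at the site where compounds 1 and 2 differ matters more, since chloro gives a 14-fold higher number from compound 2 to compound 4 (1.15 log units; beyond the scatter) and also a 2.7-fold higher number from compound 1 to compound 4 (0.43 log units; beyond the scatter). Nothing available explains these results.

On these data alone, whether an amine or a carboxylic acid in place of methoxy would give a similar number remains open. So does the effect of fluoro in place of chloro.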